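This account rests on a few compounds, and the source may have more. Where it says the series, first, only, none or still open, it means among the compounds named here.

The shared core is that of compound 1 `COc1cc(OC)c(-c2coc3cc(OCc4ccccc4F)ccc3c2=O)cc1OC`. In a functional assay on A-375 cells (Homo sapiens) for antiproliferative activity, read by MTT assay, with a stated time of 24 h (a higher number here means a weaker inhibitor, a lower number a stronger inhibitor), compound 1 gives 2100 nM. Compound 3 `COc1cc(OC)c(-c2coc3cc(OCc4cccc(Br)c4)ccc3c2=O)cc1OC` gives 1120 nM in this assay, a step of a 1.9-fold lower number from compound 1 to compound 3 (0.27 log units; within the scatter). Compound 2 `COc1cc(OC)c(-c2coc3cc(OCc4ccc([N+](=O)[O-])cc4)ccc3c2=O)cc1OC` reaches only a limit of this assay, > 10000 nM. That limit, (the limit of > 10000 nM in this assay, at which 1 of the 3 values shown sits), makes the step of an at least 4.7-fold higher number from compound 1 to compound 2 (0.67 log units; beyond the scatter), and from the other side an at least 8.9-fold lower number from compound 2 to compound 3 (0.95 log units; beyond the scatter). Of the two numbers shown, compound 1 stands highest, with compound 3 nearest.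

Compound 4 `COc1cc(OC)c(-c2coc3cc(OCc4ccc(C(F)(F)F)cc4)ccc3c2=O)cc1OC` carries the change (4-(trifluoromethyl)phenyl in place of 2-fluorophenyl on a saturated chain carbon bound to an oxygen on an aromatic ring). For the measured compounds named here, two measured steps bear on it: the move to 3-bromophenyl, within the scatter, and the move to 4-nitrophenyl, which pushed the value out to a limit. Both 4-nitrophenyl and 4-(trifluoromethyl)phenyl are substituted in the same named way, so a higher number than compound 1 is expected, likely modest, though a limit cannot be ruled out. Compound 4 is therefore estimated at 4500 nM, between 1500 nM and 12000 nM. That estimate means an expected step of a 2.1-fold higher number from compound 1 to compound 4 (0.33 log units; beyond the scatter).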

Compound 4, half-maximal inhibitory concentration: 2280 nM
Estimate against measurement, compound 4: 2.0-fold (0.30 log units) above, within the range that was stated.
By their numbers in this assay, from the lowest: compounds 3, 1 and 4 (each within the scatter of the next, the first and the last beyond it). At a limit, above all of these: compound 2.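

The 4-nitrophenyl result does not extend to every group named in that way: in this assay, 4-(trifluoromethyl)phenyl in place of 2-fluorophenyl on this saturated chain carbon gives a 1.1-fold higher number from compound 1 to compound 4 (0.04 log units; within the scatter), while the comparison with 3-bromophenyl gives a 2.0-fold higher number from compound 3 to compound 4 (0.31 log units; beyond the scatter). At the same place, trifluoromethyl in place of nitro on an aromatic carbon gives an at least 4.3-fold lower number from compound 2 to compound 4 (0.64 log units; beyond the scatter). That step has only a lower bound, since compound 2 stands at a limit and not at a number: the limit of > 10000 nM in this assay, at which 1 of the 4 values shown sits.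

The compounds shown leave open how an amine or a carboxylic acid in place of nitro on an aromatic carbon would read in this assay. They also do not separate each group from its place on the ring, since bromine appears only in 3-bromophenyl and trifluoromethyl only in 4-(trifluoromethyl)phenyl.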